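Chain Lengthening on the Enamide: Notes on Compounds 1 to 4

The compounds below may be only part of what the source reports. "The series", "measured", "known", "first", "only" and "open" are said of these compounds alone.

Measured compounds:
compound 1 `CC/C=C/C(=O)Nc1cccc(Oc2nc(Nc3cccc(OC)c3)nc3c2CSCC3)c1`: 27200 nM
compound 2 `COc1cccc(Nc2nc3c(c(Oc4cccc(NC(=O)/C=C/C(C)C)c4)n2)CSCC3)c1`: > 50000 nM (a limit of the assay, not a number)
compound 3 `C/C=C/C(=O)Nc1cccc(Oc2nc(Nc3cccc(C#N)c3)nc3c2CSCC3)c1`: 12800 nM

In a functional assay on HeLa cells (Homo sapiens) for antiproliferative activity, read by MTT assay, with a stated time of 72 h (a lower number here means a stronger inhibitor, a higher number a weaker inhibitor), compound 1 gives 27200 nM. Compound 2 carries methyl in place of hydrogen on a saturated chain carbon bound to a double-bonded chain carbon and a saturated chain carbon and returns only a limit, so the step of an at least 1.8-fold higher number from compound 1 to compound 2 (0.26 log units; that floor lies within the scatter) is a floor; its size is set by the limit of > 50000 nM in this assay, at which 1 of the 3 values shown sits. Compound 3 stands at 12800 nM; how its core differs from that of compound 1 is not broken down here.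

Compound 4 `CC/C=C/C(=O)Nc1cccc(Oc2nc(Nc3cccc(C#N)c3)nc3c2CSCC3)c1` is not yet measured. It differs from compound 3 by methyl in place of hydrogen on a saturated chain carbon bound to a double-bonded chain carbon. The place is not word for word the same as in the step from compound 1 to compound 2, where the carbon is also bound to a saturated chain carbon, so this is the same kind of change rather than the same one.

The step of a 1.7-fold higher number from compound 3 to compound 4 (0.24 log units; within the scatter) is expected, resting on the direction seen in an at least 1.8-fold higher number from compound 1 to compound 2 (0.26 log units; that floor lies within the scatter) with compound 2 sitting at the limit of > 50000 nM in this assay, at which 1 of the 3 values shown sits. Compound 4 is estimated at 22000 nM, between 8000 nM and 50000 nM.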

Compound 4, half-maximal inhibitory concentration: 31800 nM
Compound 4: middle estimate off by 1.4-fold (0.16 log units), on the low side, and the stated range covers the measured number.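

In this assay, methyl in place of hydrogen on a saturated chain carbon bound to a double-bonded chain carbon gives a 2.5-fold higher number from compound 3 to compound 4 (0.40 log units; beyond the scatter), a modest step on the cyano-bearing core. Set beside the step on the methoxy-bearing core, the two do not conflict in direction, but their sizes cannot be compared: the same change on two cores in this assay, an at least 1.8-fold higher number (0.26 log units; that floor lies within the scatter) from compound 1 to compound 2 and a 2.5-fold higher number (0.40 log units; beyond the scatter) from compound 3 to compound 4; the limit leaves it open whether they differ. Compound 2 holds only a limit of the assay, so the two cores show at most a shared direction and no size that can be carried from one core to the other: the limit of > 50000 nM in this assay, at which 1 of the 4 values shown sits.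

With the but-1-en-1-yl chain held fixed, cyano in place of methoxy on an aromatic carbon reads a 1.2-fold higher number from compound 1 to compound 4 (0.07 log units; within the scatter), so this one pair does not separate the two groups. Still open, from the compounds shown here alone, is how a longer chain, or an amine at the end of the chain, would read in this assay on either core.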